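A few compounds are considered here, and "the series" means these few. Any claim that something is new, unique, unknown or untested is made for them only; others in the source may bear on it.

Compound 1 `Cc1cc2nn(-c3ccccc3)c(N)c2c(=O)[nH]1` carries a methyl group on the shared core. In an assay on isolated protein for inhibition of serine/threonine-protein kinase D2 (Homo sapiens), read by mobility shift assay, tested at 30 uM (a lower number here means less inhibition, a higher number more inhibition at the concentration tested (going by the name of the read-out)), compound 1 gives -1%. Compound 2 `Nc1c2c(=O)[nH]c(-c3ccccc3)cc2nn1-c1ccccc1` has a phenyl in place of that methyl, and in this assay compound 2 gives 23%. Among the compounds with values here, that single swap produces a number 24 percentage points higher from compound 1 to compound 2 (beyond the scatter), so compound 2 holds the higher of the two numbers, with compound 1 as its only neighbour. Compound 3 `Nc1c2c(=O)[nH]c(-c3ccccn3)cc2nn1-c1ccccc1` keeps everything in compound 2 except one change: pyridin-2-yl in place of phenyl on an aromatic carbon. Within the data shown here, no measured step exchanges one six-membered aromatic ring for another. Among the measured compounds shown here, the only step seen replaces a methyl with a whole phenyl, a different kind of change, so it bears on this step only loosely. The expected step is therefore a number 1 percentage points lower from compound 2 to compound 3 (within the scatter), small or none beyond the scatter. The estimate for compound 3 is 22%, with a range from 5% to 42%.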

Compound 3, a percentage reported as inhibition, at one concentration (the size of the read-out at that concentration, not a potency): 15%
For compound 3 the middle estimate is 7 percentage points above the measured one; low and high end bracket the measured number.
By their numbers in this assay, from the lowest: compound 1; then compounds 3 and 2 (each within the scatter of the next).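

In this assay the swap of phenyl for pyridin-2-yl on this aromatic carbon, next to the ring nitrogen, gives a number 8 percentage points lower from compound 2 to compound 3 (within the scatter) and so leaves no difference that can be told from the scatter, even with a ring nitrogen added. Pyridin-2-yl in place of methyl gives a number 16 percentage points higher from compound 1 to compound 3 (beyond the scatter) and shows that the gain over methyl is not confined to phenyl, although this step is modest. Nothing available explains these numbers.

From the compounds shown here alone, it remains open whether an aromatic ring is needed here at all, which cyclohexyl or a longer chain such as butyl could test. Also open, going by these compounds, is whether the place of the nitrogen in the ring matters, as pyridin-3-yl and pyridin-4-yl would show.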